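A Second Fluoro at the Limit of Measurement

The source may report more compounds than this note shows. Statements on the series, on what has been measured and on what is new or still open speak of the compounds shown alone.

Of the compounds shown here, three with the same shared core have been measured in an ADME assay on a cell-free system (plasma, Homo sapiens) for protein binding; a lower number here means a smaller unbound share, a higher number a larger unbound share of the compound. Going by the values given here, compound 1 `COc1c(F)cccc1C1CCN(c2ccn3c(CC(F)(F)F)nnc3c2C#N)CC1` gives 0.047, the only exact number among them. Compound 2 `COc1ccc(F)cc1C1CCN(c2ccn3c(CC(F)(F)F)nnc3c2Cl)CC1` reports < 0.01, which is a limit of the assay and not a number. Compound 3 `COc1cccc(F)c1C1CCN(c2ccn3c(CC4CC4)nnc3c2Cl)CC1` reports < 0.01, which is also a limit and not a number. Compound 3 therefore has no exact value and sits at the limit of < 0.01 in this assay, at which 2 of the 3 values shown sit.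

Compound 4 `COc1ccc(F)c(F)c1C1CCN(c2ccn3c(CC4CC4)nnc3c2Cl)CC1` keeps compound 3 intact except for one change, from 2-fluoro-6-methoxyphenyl to 2,3-difluoro-6-methoxyphenyl: fluoro in place of hydrogen on an aromatic carbon. The new fluoro replaces hydrogen on an aromatic carbon, ortho to a fluoro group and para to a methoxy group.

Among the compounds with values here, no two measured compounds differ in only one place, so the effect of this change in this assay has not been observed directly. The starting point for the expectation is compound 3, which holds the limit < 0.01. No shift in either direction beyond the usual scatter is expected, and the estimated change is a step that the limit leaves unreadable from compound 3 to compound 4. Compound 4 is estimated at 0.007, with an expected range from 0.003 to 0.015, and the assay may well report only a limit for it.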

Compound 4, unbound fraction: < 0.01
Compound 4 was reported as a limit; the forecaster's own chance of this, stated with the estimate: 80%; the middle value does not contradict the limit.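

In this assay compound 4 gives < 0.01, which is a limit of the assay and not a number. Going by these compounds alone, compound 3 also stands at a limit, so no step from compound 3 to compound 4 can be read. The compounds shown leave open whether the added fluoro shifts the unbound fraction at all, and in which direction.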